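Sulfonyl chalcone series: sulfur substituent change from compound 3

A few compounds are considered here, and "the series" means these few. Any claim that something is new, unique, unknown or untested is made for them only; others in the source may bear on it.

In a functional assay on DU-145 cells (Homo sapiens) for inhibition, read by trypan blue exclusion, with a stated time of 96 h (on this read-out lower numbers stand for stronger inhibition of growth and higher numbers for weaker inhibition of growth), the measured compounds stand as follows:
compound 1 `Cc1ccc(S(=O)(=O)/C(=C/c2ccccc2F)C(=O)c2ccc(Cl)cc2)cc1`: 2500 nM
compound 2 `COc1ccccc1/C=C(\C(=O)c1ccc(Cl)cc1)S(=O)(=O)c1ccc(C)cc1`: 1000 nM
compound 3 `Cc1ccc(S(=O)(=O)/C(=C/c2sccc2C)C(=O)c2ccc(Cl)cc2)cc1`: 10000 nM

Compound 3 gives the highest number of the three: a 4.0-fold higher number from compound 1 to compound 3 (0.60 log units; beyond the scatter) and a 10-fold higher number from compound 2 to compound 3 (1.00 log units; beyond the scatter), both beyond the scatter. For the measured compounds named here, the only other measured step, a 2.5-fold lower number from compound 1 to compound 2 (0.40 log units; beyond the scatter), also alters the group on the double-bonded chain carbon.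

Compound 4 `Cc1ccsc1/C=C(\C(=O)c1ccc(Cl)cc1)S(=O)(=O)Cc1ccc(F)cc1` differs from compound 3 at the sulfonyl sulfur: 4-fluorobenzyl in place of 4-methylphenyl on a sulfonyl sulfur. Going by the values given here, no measured step changes the group on the sulfonyl sulfur, so none bears directly on this step; the three measured steps all lie elsewhere. Without a bearing precedent, a step within the scatter is expected in this assay. Compound 4 is therefore estimated at 10000 nM, range 3000 nM to 30000 nM, meaning an expected step of no change at the digits printed from compound 3 to compound 4 (within the scatter).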

Compound 4, concentration for 50% growth inhibition: 10000 nM
Compound 4: middle estimate and measured number agree at the digits printed; the range from low to high includes it.
By their numbers in this assay, from the lowest: compound 2; then compound 1; then compounds 3 and 4 (each within the scatter of the next).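

In this assay, the change at the sulfonyl sulfur gives no change at the digits printed from compound 3 to compound 4 (within the scatter) with 4-fluorobenzyl in place of 4-methylphenyl. This position therefore accepts this exchange with the 3-methylthiophen-2-yl group in place, whereas all three measured changes on the double-bonded chain carbon went beyond the scatter. No available evidence bears on this result.

Still open, from the compounds shown here alone, is whether the exchange behaves alike with the 2-methoxyphenyl group of compound 2 in place. Also open, going by these compounds, is how a group carrying an amine or a carboxylic acid would fare on the sulfonyl sulfur.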